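Cathepsin S series: benzyl ether substituent swap notes

The source may hold more compounds than are shown below. What is called first, only, known or untested is meant among the compounds shown, and "the series" means these compounds.

Measured compounds: compound 1 `CC(C)C[C@H](NC(=O)N1CCOCC1)C(=O)N[C@H](C#N)COCc1cccc(Cl)c1` and compound 2 `CC(C)C[C@H](NC(=O)N1CCOCC1)C(=O)N[C@H](C#N)COCc1ccc(Cl)cc1`. In an assay for inhibition of cathepsin S (Homo sapiens) (on this read-out higher numbers stand for weaker inhibition and lower numbers for stronger inhibition), compound 1 gives 9 nM. In this assay compound 2 gives 27 nM.

Within the data shown here, compound 2 has the higher of the two numbers so far; its nearest neighbour is compound 1, and the only measured step, a 3.0-fold higher number from compound 1 to compound 2 (0.48 log units; beyond the scatter), is beyond the scatter. This step changes the same ring position pattern that the next change touches, so it is the only one that bears on it, and it shows that moving the chlorine on this ring can shift the number by a modest amount.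

Compound 3 `Cc1ccccc1COC[C@@H](C#N)NC(=O)[C@H](CC(C)C)NC(=O)N1CCOCC1` is not yet measured. It differs from compound 2 in one place: 2-methylphenyl in place of 4-chlorophenyl on a saturated chain carbon bound to an oxygen on a saturated carbon. Nothing measured speaks to a 2-methylphenyl group here, so the direction is open. Among the measured compounds shown here, the single relevant step suggests a shift of similar or smaller size. The expected step is a 1.4-fold lower number from compound 2 to compound 3 (0.13 log units; within the scatter). For compound 3 the estimate in this assay is 20 nM, with a range from 5 nM to 80 nM.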

Compound 3, half-maximal inhibitory concentration: 19 nM
Beside the measured number, compound 3's estimate is 1.1-fold (0.02 log units) above it; the range from low to high includes it.
By their numbers in this assay, from the lowest: compound 1; then compounds 3 and 2 (each within the scatter of the next).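

In this assay the exchange of 4-chlorophenyl for 2-methylphenyl gives a 1.4-fold lower number from compound 2 to compound 3 (0.15 log units; within the scatter) and so does not separate these two groups, which shows that this place on the benzyl ether can carry a ring with no chlorine and keep a number in the same range. The comparison with the 3-chlorophenyl group gives a 2.1-fold higher number from compound 1 to compound 3 (0.32 log units; beyond the scatter) and leaves compound 1 as the strongest inhibitor of the three, so the advantage seen so far belongs to 3-chlorophenyl alone and not to every substituted phenyl group at this place. No measured data on hand offer an explanation for either step.

Both the identity of the substituent and its place on the ring change in these two new steps, so the compounds shown do not tell the contribution of one from that of the other; 2-chlorophenyl and 3-methylphenyl would be the groups that separate them. Also open, on these data alone, is how the number responds when the ring carries a methoxy group, an amine or a carboxylic acid, or when two substituents stand on it together.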